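Tert-butylamino for piperidinyl on a fused core

The source may hold more compounds than are shown below. What is called first, only, known or untested is meant among the compounds shown, and "the series" means these compounds.

The study measures an ADME assay on Vero cells (Chlorocebus sabaeus) for cytotoxicity; on this read-out lower numbers stand for higher toxicity in this test and higher numbers for lower toxicity in this test. Compound 1 `Fc1ccc(-c2nn3c(NC4CCCC4)cccc3c2-c2ccnc(NC3CCCC3)n2)cc1` carries a cyclopentylamino group on its fused core. In this assay compound 1 gives > 160000 nM, which is a limit of the assay rather than a number. Compound 2 `Fc1ccc(-c2nn3c(N4CCCCC4)nccc3c2-c2ccnc(NC3CCCC3)n2)cc1` carries a piperidin-1-yl group at the corresponding carbon. In this assay compound 2 gives > 40000 nM, again a limit and not a measured number, so compound 2 stands at the edge of what the test resolves, as does compound 1 in its own sentence (the limit of > 160000 nM in this assay, at which 1 of the 2 values shown sits). Compound 3 `CC(C)(C)Nc1nccc2c(-c3ccnc(NC4CCCC4)n3)c(-c3ccc(F)cc3)nn12` has not yet been measured. It differs from compound 2 in one place: (tert-butyl)amino in place of piperidin-1-yl on an aromatic carbon. Among the compounds with values here, no step between measured compounds is available to calibrate this change. Given that compound 2 shows only the limit (the limit of > 40000 nM in this assay, at which 1 of the 2 values shown sits), the writer expects no step beyond the scatter, and the expected move a step that the limit leaves unreadable from compound 2 to compound 3 is therefore small. Compound 3 is estimated at 60000 nM, with a range from 20000 nM to 200000 nM, most likely reported again as a limit.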

Compound 3, half-maximal cytotoxic concentration: > 40000 nM
Compound 3 gave a limit, no number; the forecaster's own chance of this, stated with the estimate: 75%; the middle value does not contradict the limit.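

In this assay compound 3 gives > 40000 nM, a limit of the assay and not a number. Within the data shown here, compound 2 also stands at a limit, so no step between compound 2 and compound 3 can be read. The compounds shown leave open whether (tert-butyl)amino in place of piperidin-1-yl shifts this read-out at all, and at what concentration any of these compounds becomes cytotoxic.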